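A few compounds are considered here, and "the series" means these few. Any claim that something is new, unique, unknown or untested is made for them only; others in the source may bear on it.

In an ADME assay on L6 cells (Rattus norvegicus) for inhibition, read by fluorescence, with a stated time of 72 h (a lower number here means a stronger inhibitor, a higher number a weaker inhibitor), compound 1 (`O=c1ccc2cc(Oc3ccc(Cl)cc3O)ccc2o1`) gives 96200 nM and compound 2 (`O=c1ccc2ccc(Oc3ccc(Cl)cc3O)cc2o1`) gives 188000 nM and the two values lie within the usual scatter of each other, so compound 2 stands level with compound 1. Compound 3 (`Cc1cc(=O)oc2cc(Oc3ccc(Cl)cc3O)ccc12`) differs from compound 2 by methyl in place of hydrogen on an aromatic carbon (methyl in place of hydrogen on an aromatic carbon, opposite the ring oxygen). Among the compounds with values here, no measured pair shows this change. The estimated 1.3-fold lower number from compound 2 to compound 3 (0.13 log units; within the scatter) is therefore expected to stay within the scatter, with no firm direction. In this assay compound 3 is expected at 140000 nM with an estimated range from 60000 nM to 300000 nM as its span.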

Compound 3, half-maximal inhibitory concentration: 85900 nM
Beside the measured number, compound 3's estimate is 1.6-fold (0.21 log units) above it; the range from low to high includes it.
By their numbers in this assay, from the lowest: compounds 3, 1 and 2 (each within the scatter of the next, the first and the last beyond it).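

In this assay, within the data shown here, methyl in place of hydrogen on an aromatic carbon, opposite the ring oxygen, gives a 2.2-fold lower number from compound 2 to compound 3 (0.34 log units; beyond the scatter) and so provides the first single-place step. The step is modest but lies beyond the scatter, so this position tolerates methyl here with a move towards stronger inhibition. No measured evidence bears on the origin of this step. As far as these compounds go, whether an amine, a carboxylic acid or a longer chain at this position would extend the step remains open. So does whether the same methyl change would carry over to the core of compound 1.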